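This account rests on a few compounds, and the source may have more. Where it says the series, first, only, none or still open, it means among the compounds named here.

Measured in an ADME assay on microsomes from liver (Homo sapiens) for metabolic stability, read by LC-MS, tested at 1 uM; a lower number here means slower removal, a higher number faster removal of the compound:
- Compound 1 `NCCCCCOc1ccc([C@H]2CC[C@]3(CC2)OOC2(O3)C3CC4CC(C3)CC2C4)cc1`: < 7 mL.min-1.g-1, a limit of the assay
- Compound 2 `O=S(=O)(c1ccc([C@H]2CC[C@]3(CC2)OOC2(O3)C3CC4CC(C3)CC2C4)cc1)N1CCNCC1`: 16 mL.min-1.g-1
- Compound 3 `c1cc([C@H]2CC[C@]3(CC2)OOC2(O3)C3CC4CC(C3)CC2C4)ccc1OCCCNC1CCOCC1`: 10 mL.min-1.g-1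

Compound 1 stands at the limit of < 7 mL.min-1.g-1 in this assay, at which 1 of the 3 values shown sits, so it has a limit and not a number. Compound 4 `NCCCOc1ccc([C@H]2CC[C@]3(CC2)OOC2(O3)C3CC4CC(C3)CC2C4)cc1` shortens the side chain of compound 1, from 5-aminopentyl to 3-aminopropyl: amino in place of 2-aminoethyl on a saturated chain carbon, three bonds along the chain from an oxygen on an aromatic ring. The measured step at this same place is an at least 1.4-fold higher number from compound 1 to compound 3 (0.15 log units; that floor lies within the scatter). A change of the whole side group gave an at least 2.2-fold higher number from compound 1 to compound 2 (0.35 log units; beyond the scatter), but that is a much larger change. Both steps start from a limit, and neither shortens the chain, so no step beyond the scatter is expected. The expected step is a number no lower from compound 1 to compound 4 (the limit leaves the size open). For compound 4 the estimate is 7 mL.min-1.g-1, with an expected range of 4 mL.min-1.g-1 to 14 mL.min-1.g-1.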

Compound 4, intrinsic clearance in microsomes: < 7 mL.min-1.g-1
Compound 4: no number, only a limit (the forecaster's own chance of this, stated with the estimate: 45%); the middle value sits exactly at the limit.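

In this assay, shortening the 5-aminopentyl chain of compound 1 to the 3-aminopropyl chain of compound 4 leaves a limit and not a number at both lengths, so the step between these two compounds cannot be read: the limit of < 7 mL.min-1.g-1 in this assay, at which 2 of the 4 values shown sit.

Taking oxan-4-yl off the amine nitrogen gives an at least 1.4-fold lower number from compound 3 to compound 4 (0.15 log units; that floor lies within the scatter). Replacing the (piperazin-1-yl)sulfonyl group with 3-aminopropoxy gives an at least 2.2-fold lower number from compound 2 to compound 4 (0.35 log units; beyond the scatter).

The compounds shown leave open how far the true numbers of compound 1 and compound 4 lie under the limit. They also leave open whether a 2-aminoethyl chain, or a carboxylic acid in place of the amine, would stay there.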